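The source may report more compounds than this note shows. Statements on the series, on what has been measured and on what is new or still open speak of the compounds shown alone.

Compound 1 `CC(C)CCn1ccc(-c2ccccc2)c(C#N)c1=O` is the reference point of this small set. In a functional assay on CHO cells for positive allosteric modulation of metabotropic glutamate receptor 2 (Homo sapiens), read by scintillation counting and GTPgammaS binding, with a stated time of 30 min (on this read-out higher numbers stand for larger maximal responses and lower numbers for smaller maximal responses), compound 1 gives 117%, the lowest of the three numbers shown. Compound 3 `COc1ccccc1-c1ccn(CCC(C)C)c(=O)c1C#N` gives 120% in this assay, and a number 3 percentage points higher from compound 1 to compound 3 (within the scatter). Compound 2 `COc1cccc(-c2ccn(CCC(C)C)c(=O)c2C#N)c1` gives 176%, and a number 59 percentage points higher from compound 1 to compound 2 (beyond the scatter).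

Compound 4 `CC(C)CCn1ccc(-c2ccc(Oc3ccccc3)cc2)c(C#N)c1=O` has not yet been measured in this assay. It differs from compound 1 in one place: phenoxy in place of hydrogen on an aromatic carbon. The two measured steps that bear on this are the two methoxy-for-hydrogen substitutions on the same ring, and they point in different directions in size, one large and one within the scatter. Neither involves a phenoxy group, nor the position para to a large group, so the evidence is indirect. Because the larger of the two precedents is a number 59 percentage points higher from compound 1 to compound 2 (beyond the scatter), an increase is considered plausible, but a smaller one is expected, a number 18 percentage points higher from compound 1 to compound 4 (beyond the scatter). Compound 4 is estimated to give 135% in this assay, within a range of 100% to 175%.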

Compound 4, largest response reached (Emax), in percent of the reference or control that the assay uses: 188%
The estimate for compound 4 lay 53 percentage points below the measured number; the whole stated range lies below it.
By their numbers in this assay, from the lowest: compounds 1 and 3 (each within the scatter of the next); then compound 2; then compound 4.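

With hydrogen replaced by phenoxy, which brings 7 heavy atoms and one six-membered aromatic ring of carbon only, this assay shows a number 71 percentage points higher from compound 1 to compound 4 (beyond the scatter) at this place on an aromatic carbon, para to a large group. The earlier steps shown here involved only methoxy and so did not show that a phenoxy group at this place can go with a large rise in maximal response. No measurement shown here accounts for the size of this step.

On these data alone, it remains open what a phenyl group joined directly to the ring, or a benzyloxy group, would give at this place, so the part played by the oxygen and the added ring cannot be told apart. As far as these compounds go, the effect of an amine or a carboxylic acid on the outer phenoxy ring also remains open.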